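Piperidinyl replacing tetrazolyl on the shared core

This account rests on a few compounds, and the source may have more. Where it says the series, first, only, none or still open, it means among the compounds named here.

Measured compounds:
Compound 1 `CCC(C)(C)Cc1c[nH]c(CCc2ccc(-c3cccc(N)n3)cc2)n1`: 37 nM
Compound 2 `CCC(C)(C)Cc1c[nH]c(CCc2ccc(-c3cccnc3)cc2)n1`: 131 nM
Compound 3 `CCC(C)(C)Cc1c[nH]c(CCc2ccc(-n3ncnn3)cc2)n1`: 422 nM

All three share one core and differ only in the group attached on an aromatic carbon. In a functional assay on HEK293 cells for agonist activity at Bombesin receptor subtype-3 (Homo sapiens), read by luminescence and calcium flux, with a stated time of 10 min (a lower number here means that less compound is needed, a higher number that more compound is needed for the effect), compound 3 gives the highest number of the three; the step of a 3.2-fold higher number from compound 2 to compound 3 (0.51 log units; beyond the scatter) is modest, and the step of an 11-fold higher number from compound 1 to compound 3 (1.06 log units; beyond the scatter) is large, so compound 3 needs the most compound for the effect among those measured.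

Compound 4 `CCC(C)(C)Cc1c[nH]c(CCc2ccc(N3CCCCC3)cc2)n1` differs from compound 3 in one place: piperidin-1-yl in place of 2H-tetrazol-2-yl on an aromatic carbon The group that enters is a six-membered non-aromatic ring with one nitrogen, whereas every group seen so far at that place is aromatic. Among the measured compounds shown here, no measured step swaps an aromatic group for a non-aromatic one here. The measured steps of a 3.5-fold higher number from compound 1 to compound 2 (0.55 log units; beyond the scatter) and a 3.2-fold higher number from compound 2 to compound 3 (0.51 log units; beyond the scatter) show that exchanging the group at this place moves the number by modest amounts, and together they span a large range. Given that spread, compound 4 is expected to land somewhere between the extremes seen, most likely with a lower number than compound 3, so the step of a 2.1-fold lower number from compound 3 to compound 4 (0.32 log units; beyond the scatter) is expected. Compound 4 is therefore estimated at 200 nM, within a range of 40 nM to 1000 nM.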

Compound 4, half-maximal effective concentration: 171 nM
Beside the measured number, compound 4's estimate is 1.2-fold (0.07 log units) above it, and the stated range covers the measured number.
By their numbers in this assay, from the lowest: compound 1; then compounds 2 and 4 (each within the scatter of the next); then compound 3.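

The first non-aromatic ring at this place on the shared core holds its own in this assay: a 2.5-fold lower number from compound 3 to compound 4 (0.39 log units; beyond the scatter), so an aromatic ring is not needed here to improve on 2H-tetrazol-2-yl. The aromatic pyridin-3-yl and the non-aromatic piperidin-1-yl cannot be told apart, as a 1.3-fold higher number from compound 2 to compound 4 (0.12 log units; within the scatter), while a 4.6-fold higher number from compound 1 to compound 4 (0.66 log units; beyond the scatter), which keeps 6-aminopyridin-2-yl as the group needing the least compound of the four. Nothing measured alongside these numbers accounts for the differences between the groups.

From the compounds shown here alone, what remains open is whether a non-aromatic ring can match compound 1 at this place, which a piperidine ring carrying an amine or a morpholine ring would help to test. It also remains unclear how much of the difference between 6-aminopyridin-2-yl and pyridin-3-yl belongs to the amine itself, since the two groups also differ in how the pyridine ring is attached, and a pyridin-2-yl group without the amine would separate these two changes.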